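This account rests on a few compounds, and the source may have more. Where it says the series, first, only, none or still open, it means among the compounds named here.

Among the compounds with values here, the series shares a core in which a selenocyanate-bearing aromatic ring carries a carbamate nitrogen, and the three measured members differ only in what sits on the carbamate oxygen. Compound 1 `N#C[Se]c1ccc(NC(=O)Oc2ccc(F)cc2)cc1` gives 48400 nM in a functional assay on HTB-54 cells (Homo sapiens) for cytotoxicity, read by MTT assay, with a stated time of 72 h; on this read-out higher numbers stand for weaker inhibition of growth and lower numbers for stronger inhibition of growth. Compound 2 `N#C[Se]c1ccc(NC(=O)Oc2ccc(Cl)cc2)cc1` gives 41400 nM in this assay, and the step of a 1.2-fold lower number from compound 1 to compound 2 (0.07 log units; within the scatter) is of no consequence. Compound 3 `CCOC(=O)Nc1ccc([Se]C#N)cc1`, the ethyl carbamate, gives 49300 nM in this assay; it carries the highest of the three numbers, yet its gaps to compound 1 and to compound 2 both lie within the scatter, so the three compounds cannot be told apart on these data.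

Compound 4 `N#C[Se]c1ccc(NC(=O)Oc2ccccc2)cc1` is the unmeasured member, and the change from compound 3 is phenyl in place of ethyl on an oxygen next to a carbonyl group. Within the data shown here, no measured step replaces ethyl by phenyl on the carbamate oxygen. Among the measured compounds shown here, the only measured step, from compound 1 to compound 2, exchanges halogens on the phenyl carbamate and bears on it only indirectly: it shows that two phenyl carbamates and the ethyl carbamate of compound 3 all give numbers within the scatter of one another. The expected step is therefore none beyond the scatter, a 1.1-fold lower number from compound 3 to compound 4 (0.04 log units; within the scatter), and compound 4 is expected to give 45000 nM in this assay, within a range from 22000 nM to 95000 nM.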

Compound 4, concentration for total growth inhibition: 50200 nM
For compound 4 the middle estimate is 1.1-fold (0.05 log units) below the measured one; the measured number falls inside the stated range.
By their numbers in this assay, from the lowest: compounds 2, 1, 3 and 4 (each within the scatter of the next).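

On an oxygen next to a carbonyl group, phenyl in place of ethyl now has a measured step in this assay: it gives a 1.0-fold higher number from compound 3 to compound 4 (0.01 log units; within the scatter) and so stays within the scatter even though one six-membered aromatic ring enters where an ethyl group leaves. The compound without a halogen also gives the halogens on the phenyl ring a direct comparison: hydrogen in place of chloro on an aromatic carbon gives a 1.2-fold higher number from compound 2 to compound 4 (0.08 log units; within the scatter) and the matching exchange of fluoro gives a 1.0-fold higher number from compound 1 to compound 4 (0.02 log units; within the scatter), so neither halogen can be told apart from hydrogen on these data. Nothing measured here speaks to why these exchanges leave the read-out within the scatter.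

The compounds shown leave open whether a longer chain, a benzyl group or a phenyl ring bearing an amine on the carbamate oxygen would give a number beyond the scatter of these four. They also leave open what a nitrile or a methyl group would do in place of the selenocyanate on the shared core.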